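The compounds below may be only part of what the source reports. "The series", "measured", "known", "first", "only" and "open" are said of these compounds alone.

Measured compounds:
Compound 1 `O=C1c2c[n+]([O-])c3ccccc3c2C(=O)c2c1c1ccccc1n2Cc1cn([C@@H]2C[C@H](O)[C@@H](CO)O2)nn1`, 50 nM
Compound 2 `CCCCN1CCN(CCCCn2c3c(c4ccccc42)C(=O)c2c[n+]([O-])c4ccccc4c2C3=O)CC1`, 1920 nM

In a functional assay on HCT-116 cells (Homo sapiens) for cytotoxicity, read by MTT assay, with a stated time of 72 h (a lower number here means a stronger inhibitor, a higher number a weaker inhibitor), compound 1 gives 50 nM, and compound 2 gives 1920 nM. Compound 1 stands lowest of the two numbers; its nearest neighbour is compound 2, whose value lies well beyond the scatter above it. Going by the values given here, no step between compounds differing in a single place is available, so the two values show only that the shared core tolerates a wide spread.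

Compound 3 `CC1(C)OC[C@@H](Cn2cc(Cn3c4c(c5ccccc53)C(=O)c3c[n+]([O-])c5ccccc5c3C4=O)nn2)O1` differs from compound 1 in one place: (2,2-dimethyl-1,3-dioxolan-4-yl)methyl in place of 4-hydroxy-5-(hydroxymethyl)oxolan-2-yl on an aromatic nitrogen. Both compounds keep the core and the five-membered aromatic ring with 3 nitrogen; only the group on its aromatic nitrogen changes, as the counted difference shows.

Among the compounds with values here, with no closely related step to lean on, the expectation is uncertain. Compound 3 is expected to sit a little above compound 1 in this assay, a step of a 3.0-fold higher number from compound 1 to compound 3 (0.48 log units; beyond the scatter) that may still fall within the scatter. Compound 3 is estimated at 150 nM, in a range from 40 nM to 600 nM.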

Compound 3, half-maximal inhibitory concentration: 340 nM
For compound 3 the middle estimate is 2.3-fold (0.36 log units) below the measured one, and the stated range covers the measured number.
By their numbers in this assay, from the lowest: compound 1; then compound 3; then compound 2.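

In this assay, going by these compounds alone, the exchange of 4-hydroxy-5-(hydroxymethyl)oxolan-2-yl for (2,2-dimethyl-1,3-dioxolan-4-yl)methyl on the aromatic nitrogen gives a 6.8-fold higher number from compound 1 to compound 3 (0.83 log units; beyond the scatter) and thereby shows, for the first time, that the value responds to a change at this position alone. The two groups carry the same count of heavy atoms, so the step arises with that count unchanged, while the hydrogen-bond donors go from 2 to 0, the acceptors from 3 to 2 and the defined stereocentres from 3 to 1, and the ring gains a second hetero atom. Nothing measured here gives a reason for the step.

All of these differences arrive together in a single exchange, so the compounds shown leave open which of them, if any, goes with the higher number. As far as these compounds go, it also remains open where an open-chain diol, an amine or a carboxylic acid on the same aromatic nitrogen would fall relative to compound 1 and compound 3.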